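Compound 3 to compound 4: methyl out, chloro in

The compounds below may be only part of what the source reports. "The series", "measured", "known", "first", "only" and "open" are said of these compounds alone.

In a functional assay on PC-3 cells (Homo sapiens) for antiproliferative activity, read by MTT assay, with a stated time of 96 h (on this read-out lower numbers stand for stronger inhibition of growth and higher numbers for weaker inhibition of growth), compound 1 `COc1cccc2ccc(Nc3cc(Cl)ccn3)nc12` gives 11900 nM and compound 2 `COc1ccc(Cl)c2ccc(Nc3ccccn3)nc12` gives 29200 nM. Compound 3 `COc1ccc(Cl)c2ccc(Nc3cc(C)ccn3)nc12` gives > 30000 nM, which is a limit and not a number, and it stands at the limit of > 30000 nM in this assay, at which 1 of the 3 values shown sits. Compound 4 `COc1ccc(Cl)c2ccc(Nc3cc(Cl)ccn3)nc12` carries chloro in place of methyl on an aromatic carbon, opposite the ring nitrogen: chloro in place of methyl on an aromatic carbon. For the measured compounds named here, the only measured step at that carbon is an at least 1.0-fold higher number from compound 2 to compound 3 (0.01 log units; that floor lies within the scatter), so it sets no size. Compound 1 has the same 4-chloropyridin-2-yl on a different core and gives 11900 nM, which points to a modest move toward stronger inhibition. The expected change is an at least 1.5-fold lower number from compound 3 to compound 4 (0.19 log units; that floor lies within the scatter). Compound 4 is estimated at 19000 nM, with an expected range of 8000 nM to 35000 nM.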

Compound 4, concentration for 50% growth inhibition: > 30000 nM
Compound 4: only a limit was reported; the forecaster's own chance of this, stated with the estimate: 30%; middle value at least 1.5-fold (0.19 log units) from the limit.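

In this assay the swap from 4-methylpyridin-2-yl to 4-chloropyridin-2-yl cannot be read, since compound 3 and compound 4 both rest on a limit: the limit of > 30000 nM in this assay, at which 2 of the 4 values shown sit.

At this carbon, chloro in place of hydrogen gives an at least 1.0-fold higher number from compound 2 to compound 4 (0.01 log units; that floor lies within the scatter), which is a floor and sets no size. The clearer signal comes from the chloro added to the core with 4-chloropyridin-2-yl held fixed, which gives an at least 2.5-fold higher number from compound 1 to compound 4 (0.40 log units; beyond the scatter).

Going by these compounds, whether an amine or a carboxylic acid at this carbon would bring the chlorinated core into the readable range stays open. So does how the core of compound 1 responds to hydrogen or methyl there.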